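Sulfanyl series: methylsulfanyl to propargylsulfanyl step

A few compounds are considered here, and "the series" means these few. Any claim that something is new, unique, unknown or untested is made for them only; others in the source may bear on it.

Measured compounds:
compound 1 `CSc1cnc2ccccc2c1SCC#CCOC(=O)/C=C/c1ccccc1` — 9.4 ug/mL
compound 2 `O=C(/C=C/c1ccccc1)OCC#CCSc1cnc2ccccc2c1Cl` — 11.4 ug/mL

In a functional assay on B16 cells (Mus musculus) for antiproliferative activity, with a stated time of 72 h (a lower number here means a stronger inhibitor, a higher number a weaker inhibitor), compound 1 gives 9.4 ug/mL and compound 2 gives 11.4 ug/mL. The two values lie within the scatter of each other, so neither compound can be set apart from the other. Compound 1 carries the lowest number shown, with compound 2 the closest to it.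

Compound 3 `C#CCSc1cnc2ccccc2c1SCC#CCOC(=O)/C=C/c1ccccc1` has not yet been measured. It differs from compound 1 in one place: ethynyl in place of hydrogen on a saturated chain carbon bound to a sulfur. Among the compounds with values here, no step between measured compounds covers this change, so its size has no direct precedent. The expectation for this assay is a step no larger than the usual scatter, with no preferred direction.

Compound 3 is therefore expected to come out at about 9.5 ug/mL, within 4.5 ug/mL to 20 ug/mL. The implied step a 1.0-fold higher number from compound 1 to compound 3 (0.00 log units; within the scatter) is estimated to stay within the scatter.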

Compound 3, concentration for 50% inhibition: 14.7 ug/mL
For compound 3 the middle estimate is 1.5-fold (0.19 log units) below the measured one; low and high end bracket the measured number.
By their numbers in this assay, from the lowest: compounds 1, 2 and 3 (each within the scatter of the next).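

In this assay, the exchange of methylsulfanyl for propargylsulfanyl gives a 1.6-fold higher number from compound 1 to compound 3 (0.19 log units; within the scatter) and this step lies within the scatter, so compound 1 and compound 3 cannot be set apart. Within the data shown here, this is the first direct reading of a change at this place, a saturated chain carbon bound to a sulfur, and it shows that ethynyl in place of hydrogen, with its triple bond outside aromatic rings, is carried without a step beyond the scatter. No measurement in hand bears on why the numbers fall as they do.

Going by these compounds, whether any group at this place can move the number beyond the scatter stays open, for example a longer chain, a benzyl group or a chain ending in an amine. A single exchange also cannot show whether the same outcome would hold on a different core.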